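Exchanging a 1-phenylethyl group for a hexyl chain

The source may hold more compounds than are shown below. What is called first, only, known or untested is meant among the compounds shown, and "the series" means these compounds.

Of the compounds shown here, three sharing one core have been measured in a functional assay on Right cardiac atrium for agonist activity at histamine H2 receptor (Cavia porcellus), with a stated time of 30 min, in the presence of a further agent that is not named here; on this read-out higher numbers stand for larger maximal responses and lower numbers for smaller maximal responses. Compound 1 `CCCCCNC(=O)/N=C(\N)NCCCc1sc(N)nc1C` gives 0.78. Compound 2 `Cc1nc(N)sc1CCCN/C(N)=N/C(=S)N[C@H](C)c1ccccc1` gives 0.87. Compound 3 `Cc1nc(N)sc1CCCN/C(N)=N/C(=O)N[C@@H](C)c1ccccc1` gives 1.08, the highest of the three: compound 2 lies lower, and the gap is beyond the scatter, while the step a number 0.30 higher from compound 1 to compound 3 (beyond the scatter) places compound 1 lowest of all.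

Compound 4 `CCCCCCNC(=O)/N=C(\N)NCCCc1sc(N)nc1C` has not been measured in this assay. It differs from compound 3 in one place: hexyl in place of 1-phenylethyl on an amide-type nitrogen. Going by the values given here, the only measured step that bears on this change is the one from compound 1 to compound 3, which exchanged pentyl for 1-phenylethyl on the same amide-type nitrogen and raised the response by a modest but clear amount. Compound 4 goes the other way, returning to a plain chain, hexyl rather than pentyl, so a drop of about the same size is expected: a number 0.28 lower from compound 3 to compound 4 (beyond the scatter). The value of compound 4 is therefore estimated at 0.8, with a range from 0.65 to 0.97.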

Compound 4, intrinsic activity: the largest response reached, as a fraction of the reference agonist's: 0.95
For compound 4 the middle estimate is 0.15 below the measured one, within the range that was stated.
By their numbers in this assay, from the lowest: compounds 1, 2 and 4 (each within the scatter of the next, the first and the last beyond it); then compound 3.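

In this assay, hexyl in place of 1-phenylethyl on the amide-type nitrogen gives a number 0.13 lower from compound 3 to compound 4 (beyond the scatter), so a chain with no ring keeps most of the response, and an aromatic ring at this position is not required for a high value. Adding one carbon to the plain chain, going from pentyl to hexyl, gives a number 0.17 higher from compound 1 to compound 4 (beyond the scatter), which shows that the response at this position also changes with chain length and not only with the presence of a ring. No data are available to explain either step.

Two chains cannot establish a trend with length, so heptyl or octyl could continue the rise or reverse it. A benzyl group on the same nitrogen would show how much the response depends on the methyl branch of 1-phenylethyl.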